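The source may report more compounds than this note shows. Statements on the series, on what has been measured and on what is new or still open speak of the compounds shown alone.

Two compounds sharing the same core and a sulfonamide arm have been measured. Compound 1 `CC(C)NS(=O)(=O)Cc1noc2ccccc12` and compound 2 `CNS(=O)(=O)Cc1noc2ccc(Cl)cc12` were tested in a functional assay on the whole organism (strain STD-dd) with Mus musculus as the target, in the maximal electroshock model, with a stated time of 2 h; on this read-out lower numbers stand for an effect already at smaller amounts and higher numbers for an effect only at larger amounts of compound. In this assay compound 1 gives 56 mg/kg, and compound 2 gives 20 mg/kg. Compound 2 therefore stands at the lower of the two numbers, and compound 1 lies higher by a gap beyond the usual scatter.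

Compound 3 `CC(C)NS(=O)(=O)Cc1noc2ccc(Cl)cc12` is not yet measured. It differs from compound 2 in one place: isopropyl in place of methyl on a sulfonamide nitrogen. Within the data shown here, the two measured compounds differ from each other in two places at once, so no single step isolates the effect of this change, and the numbers give no direct guide to it.

A small step towards a higher number is expected, a 1.5-fold higher number from compound 2 to compound 3 (0.18 log units; within the scatter), close to the edge of the scatter. Compound 3 is accordingly expected to give about 30 mg/kg, within a range from 14 mg/kg to 70 mg/kg.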

Compound 3, dose for half-maximal effect: 100 mg/kg
Compound 3: middle estimate off by 3.3-fold (0.52 log units), on the low side; measured number above the stated range.
By their numbers in this assay, from the lowest: compound 2; then compounds 1 and 3 (each within the scatter of the next).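

In this assay, the change on the sulfonamide nitrogen can now be read alone: isopropyl in place of methyl gives a 5.0-fold higher number from compound 2 to compound 3 (0.70 log units; beyond the scatter), a step beyond the usual scatter, so this position is not indifferent to the change when the chloro group is present. Chloro in place of hydrogen on an aromatic carbon can also be read alone, with isopropyl on the nitrogen, and gives a 1.8-fold higher number from compound 1 to compound 3 (0.25 log units; within the scatter), a step within the scatter that shows no clear effect of chloro in that setting. Nothing available explains the size of either step. The compounds shown leave open how ethyl, cyclopropyl or a plain hydrogen on the sulfonamide nitrogen would read. They also leave open whether chloro in place of hydrogen would give a similar step with methyl on that nitrogen.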